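This account rests on a few compounds, and the source may have more. Where it says the series, first, only, none or still open, it means among the compounds named here.

Measured so far:
compound 1 `O=c1oc2ccccc2c2nc3c(ccc4cc[nH]c43)c(-c3ccc(Br)cc3)c12` — 70700 nM
compound 2 `O=c1cc(O)c2cc(F)ccc2o1` — 70700 nM

In a functional assay on B16-F10 cells (Mus musculus) for cytotoxicity (a higher number here means a weaker inhibitor, a lower number a stronger inhibitor), compound 1 gives 70700 nM, and compound 2 gives 70700 nM; the two values are level at the digits shown and lie within the usual scatter, so the two compounds cannot be told apart on this number. Compound 3 `COc1ccc(-c2c3ccc4cc[nH]c4c3nc3c2c(=O)oc2ccccc23)cc1` is not yet measured. It differs from compound 1 by methoxy in place of bromo on an aromatic carbon. Among the measured compounds shown here, no pair of measured compounds that differ in one place is known here, so this change has no precedent to lean on. The step is expected to be a 1.0-fold lower number from compound 1 to compound 3 (0.00 log units; within the scatter), that is, none beyond the scatter. Compound 3 is estimated at 70000 nM, with a range from 30000 nM to 120000 nM.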

Compound 3, half-maximal inhibitory concentration: 70700 nM
Beside the measured number, compound 3's estimate is 1.0-fold (0.00 log units) below it, and the stated range covers the measured number.
By their numbers in this assay, from the lowest: compounds 1, 2 and 3 (each within the scatter of the next).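

In this assay, among the compounds shown here, the swap of 4-bromophenyl for 4-methoxyphenyl gives no change at the digits printed from compound 1 to compound 3 (within the scatter) and is the first step between compounds that differ in one place. At this position on the aromatic ring, methoxy and bromo cannot be told apart on this number. The compounds shown leave open whether an amine, a carboxylic acid or a longer chain at the same position would shift the value beyond the scatter. No measured evidence is available that could account for this result.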